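Bromo to methylpyrazolyl on the shared core: solubility notes

A few compounds are considered here, and "the series" means these few. Any claim that something is new, unique, unknown or untested is made for them only; others in the source may bear on it.

Going by the values given here, compound 1 `Cc1cc(NCc2ccccn2)n2ncc(Br)c2n1` is the only member of this set with a full number in a physicochemical assay for solubility, read by HPLC, using the shake flask method, measured as kinetic solubility, with a stated time of 2 h, at pH 7.4; on this read-out lower numbers stand for lower solubility and higher numbers for higher solubility. In this assay compound 1 gives 89300 nM. Compound 2 `Cc1cc(NCc2ccco2)n2nc(C)c(-c3ccccc3)c2n1` is reported only as a limit of the assay. In this assay compound 2 gives < 5000 nM, which is a limit and not a number. Among the compounds with values here, one of the two values therefore sits at the limit of < 5000 nM in this assay, at which 1 of the 2 values shown sits, so compound 1 stands alone as the measured reference point, and no step between measured compounds can be drawn.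

Compound 3 `Cc1cc(NCc2ccccn2)n2ncc(-c3ccn(C)n3)c2n1` differs from compound 1 by 1-methyl-1H-pyrazol-3-yl in place of bromo on an aromatic carbon. Within the data shown here, no measured pair informs the direction of such a change here; the expectation is for a modest downward step, close to the scatter. The step from compound 1 to compound 3 in this assay is estimated as a 1.6-fold lower number from compound 1 to compound 3 (0.21 log units; within the scatter). Compound 3 is expected to show 55000 nM, with a range from 15000 nM to 180000 nM.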

Compound 3, solubility: 188000 nM
Compound 3: middle estimate off by 3.4-fold (0.53 log units), on the low side, outside the stated range (above it).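

Notes on the aromatic carbon two ring bonds from the ring nitrogen: with 1-methyl-1H-pyrazol-3-yl in place of bromo, this assay gives a 2.1-fold higher number from compound 1 to compound 3 (0.32 log units; beyond the scatter) and so supplies the first measured step in the series. The step is modest, yet it shows that this position tolerates a five-membered aromatic ring of 6 heavy atoms without a fall in the read-out, at least on the core of compound 1. Nothing measured in the series accounts for the step.

Open, on these data alone, is how a primary amine or a carboxylic acid on the same carbon would read in this assay, and whether the gain holds for other aromatic rings there. As far as these compounds go, compound 2 gives < 5000 nM, a limit and not a number, and it differs from compound 1 in more than one place, so the change remains untested on any other amine side chain.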